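The compounds below may be only part of what the source reports. "The series", "measured", "known", "first", "only" and "open" are said of these compounds alone.

Measured compounds in an assay on CHO cells for displacement of a labelled ligand from prostaglandin E2 receptor EP3 subtype (Mus musculus), read by scintillation counting, with a stated time of 60 min; a lower number here means a stronger inhibitor, a higher number a weaker inhibitor:
- compound 1 `O=C(O)CCCSCCN1C(=O)CC[C@@H]1/C=C/[C@@H](O)Cc1cccc(-c2cc3ccccc3o2)c1`: > 10000 nM
- compound 2 `O=C(O)CCCSCCN1C(=O)CC[C@@H]1/C=C/[C@@H](O)Cc1cccc(OCc2ccncc2)c1`: > 10000 nM
- compound 3 `O=C(O)c1csc(SCCN2C(=O)CC[C@@H]2/C=C/[C@@H](O)Cc2cccc(-c3ccccc3)c2)n1`: 4300 nM

Compound 1 sits at the limit of this assay, > 10000 nM, which is a limit and not a number. Compound 2 likewise gives only a limit, > 10000 nM. Going by the values given here, compound 3 is the only compound with a number, 4300 nM; the other two values rest at the limit of > 10000 nM in this assay, at which 2 of the 3 values shown sit. The step that the two limits leave unreadable from compound 1 to compound 2 cannot be read, both ends being limits.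

Compound 4 `Cc1ccc2oc(-c3cccc(C[C@H](O)/C=C/[C@H]4CCC(=O)N4CCSc4nc(C(=O)O)cs4)c3)nc2c1` differs from compound 3 by 5-methyl-1,3-benzoxazol-2-yl in place of phenyl on an aromatic carbon. Among the compounds with values here, no measured step covers this change: the thiazole-carboxylic-acid side chain of compound 3 and compound 4 is shared with no other measured compound, and the bicyclic heteroaryl of compound 1 sits on a different side chain and gives only a limit. The size of the step is therefore uncertain. Compound 4 is expected to land near or somewhat stronger than compound 3, an estimated step of a 2.9-fold lower number from compound 3 to compound 4 (0.46 log units; beyond the scatter) in this assay. The estimate for compound 4 is 1500 nM, with a range from 200 nM to 12000 nM.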

Compound 4, inhibition constant: > 10000 nM
Compound 4: only a limit was reported; the forecaster's own chance of this, stated with the estimate: 20%; middle value at least 6.6-fold (0.82 log units) from the limit.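

Going by these compounds alone, on the aromatic carbon meta to a large group, 5-methyl-1,3-benzoxazol-2-yl in place of phenyl gives an at least 2.3-fold higher number from compound 3 to compound 4 (0.36 log units; beyond the scatter) in this assay, the first readable step at this position, and it runs toward weaker inhibition. Compound 4 gives > 10000 nM, which is a limit of the assay and not a number. With this result, compound 3 remains the only compound with a number, and the series rests mostly at one end of the scale: the limit of > 10000 nM in this assay, at which 3 of the 4 values shown sit.

How far compound 4 lies past the limit cannot be read, and steps with a limit at both ends cannot be read either. As far as these compounds go, whether methoxy, chlorine or an aminomethyl group on this aromatic carbon would match compound 3 stays open, as does whether the benzoxazolyl group without its methyl would differ from compound 4.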